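Hydroxy for Methoxy in a Weakly Active Pair

The source may report more compounds than this note shows. Statements on the series, on what has been measured and on what is new or still open speak of the compounds shown alone.

Compound 1 `COc1ccc(-c2cc3c(OC)cc(OC)cc3n(C)c2=O)cc1` was tested in a functional assay on T-24 cells (Homo sapiens) for cytotoxicity, read by colorimetric assay and MTT assay (a higher number here means a weaker inhibitor, a lower number a stronger inhibitor), where compound 1 gives 10000 nM. In the same test compound 2 `CCOC(=O)Cn1c(=O)c(-c2ccc(OC)cc2)cc2c(OC)cc(OC)cc21` gives 10000 nM, so compound 1 stands level with compound 2, and the step of no change at the digits printed from compound 1 to compound 2 (within the scatter) lies within the scatter. Compound 3 `COc1cc(OC)c2cc(-c3ccc(O)cc3)c(=O)n(C)c2c1` differs from compound 1 in one place: hydrogen in place of methyl on an oxygen on an aromatic ring. Going by the values given here, no measured step touches this oxygen, and the only step known sits elsewhere and was flat. Compound 3 is therefore expected to move by no change at the digits printed from compound 1 to compound 3 (within the scatter), staying within the scatter. Compound 3 is estimated at 10000 nM, between 5000 nM and 20000 nM.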

Compound 3, half-maximal inhibitory concentration: 10000 nM
Compound 3: middle estimate and measured number agree at the digits printed, and the stated range covers the measured number.
By their numbers in this assay, from the lowest: compounds 1, 2 and 3 (each within the scatter of the next).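

Replacing methoxy with hydroxy on the 4-methoxyphenyl group gives no change at the digits printed from compound 1 to compound 3 (within the scatter) in this assay. Going by these compounds alone, the earlier pair tested only the group on the aromatic nitrogen, so this is the first reading at the oxygen on this aromatic ring, and it too is flat. Nothing available explains why this exchange leaves the number in place.

Going by these compounds, whether an amine or a carboxylic acid at this place would give a different number stays open. So does whether changing the methoxy groups on the shared core would.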